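Adding 4-cyanophenyl to compound 3

The source may hold more compounds than are shown below. What is called first, only, known or untested is meant among the compounds shown, and "the series" means these compounds.

In a functional assay on a cell-free system (plasma, Oryctolagus cuniculus) for inhibition, with stated times of 5 min, 1 min and 6 min (on this read-out higher numbers stand for weaker inhibition and lower numbers for stronger inhibition), compound 1 (`CCOC(=O)c1c(C)nc(-c2cccc(C#N)c2)n1OC`) gives 9130 nM and compound 2 (`CCOC(=O)COn1c(-c2cccc(C#N)c2)nc(C)c1C(=O)OCC`) gives 6800 nM while compound 3 (`COn1c(-c2cccc(C#N)c2)nc(C)c1C(=O)O`) gives 7990 nM so compound 3 stands level with the other two, all three numbers lying within the usual scatter of one another.

Compound 4 (`Cc1nc(-c2cccc(C#N)c2)n(OCc2ccc(C#N)cc2)c1C(=O)O`) carries 4-cyanophenyl in place of hydrogen on a saturated chain carbon bound to an oxygen on an aromatic ring.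

Among the measured compounds shown here, two measured steps bear on this change. Ethoxycarbonyl entering at that same place gave a 1.3-fold lower number from compound 1 to compound 2 (0.13 log units; within the scatter) and hydrogen replacing ethyl on an oxygen next to a carbonyl group gave a 1.1-fold lower number from compound 1 to compound 3 (0.06 log units; within the scatter) so neither moved the number beyond the scatter. For the measured compounds named here, no measured compound carries an added aromatic ring at that place, which keeps the range wide.

The expected step is a 1.1-fold lower number from compound 3 to compound 4 (0.06 log units; within the scatter) and no shift beyond the scatter is anticipated in either direction. Compound 4 is estimated at 7000 nM in this assay (expected range 3000 nM to 16000 nM).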

Compound 4, half-maximal inhibitory concentration: 3880 nM
Compound 4: middle estimate off by 1.8-fold (0.26 log units), on the high side; the measured number falls inside the stated range.
By their numbers in this assay, from the lowest: compounds 4, 2, 3 and 1 (each within the scatter of the next, the first and the last beyond it).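

In this assay, the step of a 2.1-fold lower number from compound 3 to compound 4 (0.31 log units; beyond the scatter) is the only one shown that goes beyond the scatter, though it is modest. At this same place, the ethoxycarbonyl step of a 1.3-fold lower number from compound 1 to compound 2 (0.13 log units; within the scatter) stays within the scatter, so the position is not indifferent to every group put there, and going from methyl to 4-cyanobenzyl, with its added ring and nitrile, lowers the number rather than raising it. No measurement here accounts for this step.

The compounds shown leave open whether the ring alone produces the change or whether the nitrile on it contributes, a question that a plain benzyl group would address. They also leave open how a longer chain between the oxygen and the ring, or an amine in place of the nitrile, would read in this assay.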